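The compounds below may be only part of what the source reports. "The series", "measured", "known", "first", "only" and "open" are said of these compounds alone.

Compound 1 `C#CCSc1nc(Sc2nc3ccccc3s2)c(C#N)c(-c2cc(OC)c(OC)c(OC)c2)n1`: > 20000 nM
Compound 2 `C=CC(=O)Nc1ccccc1CN(C(=O)Nc1cccc(C(F)(F)F)c1)C1CCN(C(C)CCC)CC1`: 10200 nM

Of the compounds shown here, two have been tested in a functional assay on MCF7 cells (Homo sapiens) for antiproliferative activity, read by MTT assay, with a stated time of 72 h; a lower number here means a stronger inhibitor, a higher number a weaker inhibitor. Compound 1 reaches only the limit of the assay, > 20000 nM, so no number is known for it. Compound 2, built on an unrelated scaffold, gives 10200 nM in this assay. Compound 1 therefore stands at the point where the assay stops reporting a value, as the limit of > 20000 nM in this assay, at which 1 of the 2 values shown sits, shows.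

Compound 3 `C#CCSc1nc(Sc2nc(C)c(C)s2)c(C#N)c(-c2cc(OC)c(OC)c(OC)c2)n1` keeps the core of compound 1 and changes one group: 4,5-dimethyl-1,3-thiazol-2-yl in place of 1,3-benzothiazol-2-yl on a sulfur. Among the compounds with values here, no measured pair differs in this way, so the size of the step cannot be read from a measured comparison. Since compound 1 already sits at the limit (the limit of > 20000 nM in this assay, at which 1 of the 2 values shown sits), the step from compound 1 to compound 3 in this assay is expected to be a step that the limit leaves unreadable from compound 1 to compound 3, with no direction that clearly exceeds the scatter. Compound 3 is expected to give 25000 nM in this assay, between 8000 nM and 80000 nM, and quite possibly another limit rather than a number.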

Compound 3, half-maximal inhibitory concentration: > 20000 nM
Compound 3 was reported as a limit; the forecaster's own chance of this, stated with the estimate: 65%; the middle value does not contradict the limit.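

Compound 1 and compound 3 are both reported only as limits of the assay, not as numbers, so no step can be read for replacing 1,3-benzothiazol-2-yl with 4,5-dimethyl-1,3-thiazol-2-yl: the limit of > 20000 nM in this assay, at which 2 of the 3 values shown sit.

The compounds shown leave open how far apart compound 1 and compound 3 truly lie, and whether any group on that sulfur would give the shared core a readable value.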